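Butylamino in place of methylamino on the shared core

A few compounds are considered here, and "the series" means these few. Any claim that something is new, unique, unknown or untested is made for them only; others in the source may bear on it.

Measured so far in an assay on isolated protein for binding affinity to 5-hydroxytryptamine receptor 3A (Homo sapiens); on this read-out lower numbers stand for stronger inhibition and higher numbers for weaker inhibition:
compound 1 `COc1ccccc1-c1cc(C2CCNC2)ccc1Cl` gives 590 nM.
compound 3 `COc1ccccc1-c1cc(CN(C)C)ccc1Cl` gives 1000 nM.
compound 2 `CNCc1ccc(Cl)c(-c2ccccc2OC)c1` gives only a limit, > 10000 nM.

Compound 2 thus sits at the limit of this assay (the limit of > 10000 nM in this assay, at which 1 of the 3 values shown sits), weaker than compound 1 and compound 3 by amounts that pass the scatter. Compound 4 `CCCCNCc1ccc(Cl)c(-c2ccccc2OC)c1` differs from compound 2 by propyl in place of hydrogen on a saturated chain carbon bound to an amine nitrogen. The measured steps at the same amine are an at least 10-fold lower number from compound 2 to compound 3 (1.00 log units; beyond the scatter) and an at least 16-fold higher number from compound 1 to compound 2 (1.22 log units; beyond the scatter), both beyond the scatter and both showing that larger substitution at this amine lowers the number. The expectation for compound 4 is therefore a step of an at least 6.6-fold lower number from compound 2 to compound 4 (0.82 log units; beyond the scatter), downward. Compound 4 is estimated at 1500 nM, within 300 nM to 8000 nM.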

Compound 4, inhibition constant: > 10000 nM
Compound 4: a limit, no number; the forecaster's own chance of this, stated with the estimate: 25%; at least 6.6-fold (0.82 log units) between middle value and limit.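

Compound 4 gives only a limit, as compound 2 does, and the step between them cannot be read: the limit of > 10000 nM in this assay, at which 2 of the 4 values shown sit.

Butylamino in place of methylamino therefore shows no readable gain on this read-out, so the added propyl does not match the gain seen when methyl is placed on the amine nitrogen of compound 2 to give compound 3. The separation from the two measured amines is clear: an at least 10-fold higher number from compound 3 to compound 4 (1.00 log units; beyond the scatter), and an at least 16-fold higher number from compound 1 to compound 4 (1.22 log units; beyond the scatter).

Still open, from the compounds shown here alone, is whether an amine nitrogen carrying both butyl and methyl reads close to compound 3. Also open, going by these compounds, is whether a shorter ethylamino group stays at the limit.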